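Replacing the Ring at the Carbonyl of Compound 1

A few compounds are considered here, and "the series" means these few. Any claim that something is new, unique, unknown or untested is made for them only; others in the source may bear on it.

Among the measured compounds shown here, compound 1 `CC1CCCC(C(=O)N2CC(c3nc(-c4cccc(Cl)c4)no3)C2)C1` is one of two compounds so far measured in an assay on HEK293 cells for positive allosteric modulation of metabotropic glutamate receptor 5 (Homo sapiens), read by FLIPR; on this read-out higher numbers stand for an effect only at larger amounts of compound and lower numbers for an effect already at smaller amounts. In this assay compound 1 gives 410 nM, the lowest of the two numbers. Compound 2 `O=C(c1ccc(F)c(F)c1)N1CC(c2nc(-c3cccc(F)c3)no2)C1` stands well apart from it, farther than the usual scatter of repeated measurements; in this assay compound 2 gives 3200 nM. For the measured compounds named here, the two compounds differ in more than one place, so no single step can be read between them, and their values show only that compound 1 acts at smaller amounts than compound 2.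

Compound 3 `COC1CCN(C(=O)N2CC(c3nc(-c4cccc(Cl)c4)no3)C2)CC1` has not yet been measured. It differs from compound 1 in one place: 4-methoxypiperidin-1-yl in place of 3-methylcyclohexyl on a carbonyl carbon. Going by the values given here, no measured pair shows what this kind of exchange does, so the expectation rests on compound 1 and the size of the change alone. The estimated step is a 3.7-fold higher number from compound 1 to compound 3 (0.56 log units; beyond the scatter), a move toward higher numbers that goes somewhat beyond the scatter. Compound 3 is therefore expected to give about 1500 nM, in a range from 400 nM to 6000 nM.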

Compound 3, half-maximal effective concentration: > 10000 nM
Compound 3: no number, only a limit; the forecaster's own chance of this, stated with the estimate: 10%; middle value at least 6.6-fold (0.82 log units) from the limit.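

Among the compounds shown here, at the carbonyl carbon whose other neighbour is an amide-type nitrogen in a ring, 4-methoxypiperidin-1-yl in place of 3-methylcyclohexyl gives an at least 24-fold higher number from compound 1 to compound 3 (1.38 log units; beyond the scatter), the first large step in one place to be read in this assay. Going by these compounds, compound 3 gives only a limit in this read-out, not a number, so the true size of the step remains unknown: the limit of > 10000 nM in this assay, at which 1 of the 3 values shown sits. The result shows that this position does not treat all six-membered non-aromatic rings alike, since exchanging the ring of carbon only for one with 1 hetero atom and 1 hydrogen-bond acceptor takes the compound out of the measurable range, at least in this single pair.

The exchange alters the ring and its substituent together, so the compounds shown cannot say whether the step belongs to the ring nitrogen, the methoxy group or the two combined. A piperidin-1-yl without the methoxy group and a 4-methoxycyclohexyl would each separate these two changes, and the compounds shown leave open what either would give at this carbonyl carbon.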